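Methyl on the ring nitrogen: from compound 2 to compound 3

The source may report more compounds than this note shows. Statements on the series, on what has been measured and on what is new or still open speak of the compounds shown alone.

Of the compounds shown here, two have been measured in a functional assay on cells (Mus musculus) for cytotoxicity, read by MTT assay, with a stated time of 24 h, tested at 1 uM; on this read-out higher numbers stand for a stronger effect at the one concentration tested and lower numbers for a weaker effect. Compound 1 `COc1cc(/C=N/N(C)c2nc3ccccc3s2)cc(OC)c1O` gives 107% in this assay. Compound 2 `COc1cc(/C=N/Nc2nc3ccccc3s2)cc(OC)c1OC` gives 4% in this assay, the lowest of the two numbers; its nearest neighbour on the numbers is compound 1, which stands higher by a gap beyond the scatter. Compound 1 and compound 2 differ in more than one place, so their two values show only that one is high and the other low. Compound 3 `COc1cc(/C=N/N(C)c2nc3ccccc3s2)cc(OC)c1OC` is not yet measured. It differs from compound 2 by methyl in place of hydrogen on a nitrogen on an aromatic ring. Compound 1 carries the same methyl on that nitrogen, but the numbers do not tell which of its differences from compound 2 carries the gap. An upward step beyond the scatter, of uncertain size, is expected a number 41 percentage points higher from compound 2 to compound 3 (beyond the scatter). For compound 3 the estimate in this assay is 45%, within 5% to 100%.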

Compound 3, a percentage reported as activity, at one concentration (the size of the read-out at that concentration, not a potency): 7%
Estimate against measurement, compound 3: 38 percentage points above; the measured number falls inside the stated range.
By their numbers in this assay, from the lowest: compounds 2 and 3 (each within the scatter of the next); then compound 1.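

In this assay methyl in place of hydrogen on a nitrogen on an aromatic ring gives a number 3 percentage points higher from compound 2 to compound 3 (within the scatter) and so, at this one concentration, shows no effect of the methyl at this position. The large gap belongs to the other place: the change on the oxygen gives a number 100 percentage points lower from compound 1 to compound 3 (beyond the scatter), which ties the high number of compound 1 to the hydrogen on that oxygen, with the nitrogen methyl present. Nothing measured here accounts for this step.

Open, from the compounds shown here alone, is whether the hydrogen on that oxygen has the same weight when the nitrogen carries hydrogen rather than methyl. Also open, going by these compounds, is whether an amine in place of that hydroxyl, or a longer chain on that oxygen, would give a high or a low number.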